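Extending the Linker by One Carbon: What Compound 4 May Show

The source may report more compounds than this note shows. Statements on the series, on what has been measured and on what is new or still open speak of the compounds shown alone.

Three compounds built on a shared core differ only in the chain that carries the iodoacetamide end group. Compound 1 `O=C(CI)NCCCCCC(=O)NCCCCCCNc1ncnc2c1ncn2[C@@H]1O[C@H](COP(=O)(O)OP(=O)(O)OP(=O)(O)O)[C@@H](O)[C@H]1O` and compound 2 `O=C(CI)NCCCCCCC(=O)NCCCCCCNc1ncnc2c1ncn2[C@@H]1O[C@H](COP(=O)(O)OP(=O)(O)OP(=O)(O)O)[C@@H](O)[C@H]1O` were both tested in an assay on isolated protein for inhibition of hexokinase-1 (Rattus norvegicus), with a stated time of 6 h, tested at 10 mM (on this read-out lower numbers stand for less inhibition and higher numbers for more inhibition at the one concentration tested (going by the name of the read-out)), where compound 1 gives 0% and compound 2 gives 0%. The change between them is (((iodomethyl)carbonyl)amino)methyl in place of ((iodomethyl)carbonyl)amino on a saturated chain carbon, five bonds along the chain from a carbonyl carbon, and the resulting step is no change at the digits printed from compound 1 to compound 2 (within the scatter). Compound 3 `O=C(CI)NCCCCCC(=O)NCCCNc1ncnc2c1ncn2[C@@H]1O[C@H](COP(=O)(O)OP(=O)(O)OP(=O)(O)O)[C@@H](O)[C@H]1O` also gives 0% in this assay; the difference between the core of compound 3 and that of compound 1 is not broken down here, and the two values simply sit together.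

Compound 4 `O=C(CI)NCCCCCCC(=O)NCCCNc1ncnc2c1ncn2[C@@H]1O[C@H](COP(=O)(O)OP(=O)(O)OP(=O)(O)O)[C@@H](O)[C@H]1O` has not yet been measured. It differs from compound 3 by (((iodomethyl)carbonyl)amino)methyl in place of ((iodomethyl)carbonyl)amino on a saturated chain carbon, five bonds along the chain from a carbonyl carbon, the same change seen between compound 1 and compound 2, at the same place. Because compound 3 gives 0% and the earlier change produced no change at the digits printed from compound 1 to compound 2 (within the scatter), the step of no change at the digits printed from compound 3 to compound 4 (within the scatter) is expected to be equally small. Compound 4 is therefore estimated at 0%, with a plausible range from 0% to 10%.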

Compound 4, a percentage reported as inhibition, at one concentration (the size of the read-out at that concentration, not a potency): 0%
Compound 4: the middle estimate sits on the measured number at the digits printed; low and high end bracket the measured number.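

In this assay, putting (((iodomethyl)carbonyl)amino)methyl in place of ((iodomethyl)carbonyl)amino on the core of compound 3 gives no change at the digits printed from compound 3 to compound 4 (within the scatter). The change therefore reads the same on the two cores shown: the same change on two cores in this assay, no change at the digits printed (within the scatter) from compound 1 to compound 2 and no change at the digits printed (within the scatter) from compound 3 to compound 4, 0 percentage points apart, within the scatter of two such steps This does not show that the change is neutral in general, since all four compounds sit at the same bottom reading in this assay, and a step that starts and ends there cannot tell whether the change would raise or lower inhibition on a compound that actually inhibits the enzyme.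

The compounds shown leave open whether any member of this series gives a reading above that level in this assay. Also open, going by these compounds, is whether a longer chain such as 4-(((iodomethyl)carbonyl)amino)butyl, or an amine or a carboxylic acid in place of the ((iodomethyl)carbonyl)amino group, would give a different result.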